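This account rests on a few compounds, and the source may have more. Where it says the series, first, only, none or still open, it means among the compounds named here.

Measured compounds:
- Compound 1, `Cc1ccccc1Nc1ncnc2cc(NC(=O)CCCCCCC(=O)NO)sc12` — an assay on cells for inhibition of protein deacetylase HDAC6 (Homo sapiens), with a stated time of 3 h (a higher number here means a weaker inhibitor, a lower number a stronger inhibitor), gives for compound 1 87.6 nM
- Compound 2, `Cc1cc(F)ccc1Nc1ncnc2cc(NC(=O)CCCCCCC(=O)NO)sc12` — in this assay compound 2 gives 120 nM

Compound 2 stands at the higher of the two numbers, but the gap is only a 1.4-fold higher number from compound 1 to compound 2 (0.14 log units; within the scatter), so the two compounds cannot be told apart on these data.

Compound 3, `O=C(CCCCCCC(=O)Nc1cc2ncnc(Nc3ccc(Cl)cc3F)c2s1)NO`, is to be measured in this assay. It differs from compound 2 in one place: 4-chloro-2-fluorophenyl in place of 4-fluoro-2-methylphenyl on a nitrogen on an aromatic ring. Both groups carry the same count of heavy atoms and neither adds a hydrogen-bond donor or acceptor; only the pattern of substituents on the aromatic ring is exchanged.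

For the measured compounds named here, the single measured step that touches this part of the molecule is the one from compound 1 to compound 2, which added a fluorine to the same aromatic ring and moved the number by a 1.4-fold higher number from compound 1 to compound 2 (0.14 log units; within the scatter). Nothing measured here speaks to a chlorine on this ring or to the loss of the methyl group. Going by the values given here, with the only available precedent showing a change within the scatter, the step to compound 3 is expected to be small as well, a 1.1-fold higher number from compound 2 to compound 3 (0.03 log units; within the scatter), with no clear direction. The estimate for compound 3 in this assay is therefore 130 nM, with a range from 55 nM to 300 nM.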

Compound 3, half-maximal inhibitory concentration: 37 nM
Beside the measured number, compound 3's estimate is 3.5-fold (0.55 log units) above it, and the stated range ends above it.
By their numbers in this assay, from the lowest: compound 3; then compounds 1 and 2 (each within the scatter of the next).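

For the compounds shown here, on the aromatic ring carried by the nitrogen, this exchange gives the first change beyond the scatter in this assay: 4-chloro-2-fluorophenyl in place of 4-fluoro-2-methylphenyl gives a 3.2-fold lower number from compound 2 to compound 3 (0.51 log units; beyond the scatter), and the same group in place of 2-methylphenyl gives a 2.4-fold lower number from compound 1 to compound 3 (0.37 log units; beyond the scatter). The position therefore responds to what the ring carries, even though adding a fluorine alone left compound 1 and compound 2 within the scatter of each other, and a lower number here means a stronger inhibitor. The exchange alters several substituents at once, and no measurement in hand explains the stronger result.

The compounds shown cannot separate the contribution of the chlorine from that of losing the methyl group, a question that a 4-chloro-2-methylphenyl group on the same nitrogen would address directly. Also open, on these data alone, is how a bromine or a methoxy group would read in place of the chlorine, and whether the same exchange would give a similar step on a longer chain.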